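Replacing the Methoxycyclohexylmethyl Arm: What to Expect

A few compounds are considered here, and "the series" means these few. Any claim that something is new, unique, unknown or untested is made for them only; others in the source may bear on it.

Measured so far:
- compound 1, `N#Cc1cnc(NCc2cnccc2C(F)(F)F)cc1NC[C@H]1CC[C@H](O)CC1`, gives 2000 nM in an assay on isolated protein for inhibition of protein kinase C delta type (Homo sapiens), read by TR-FRET, with a stated time of 2 h; a lower number here means a stronger inhibitor, a higher number a weaker inhibitor
- compound 2, `CO[C@H]1CC[C@H](CNc2cc(NCc3cnccc3C(F)(F)F)ncc2C#N)CC1`, gives > 10000 nM in this assay

The value recorded for compound 2 is a limit of this assay rather than a number, as the limit of > 10000 nM in this assay, at which 1 of the 2 values shown sits, shows. Among the compounds with values here, compound 2 is therefore the weaker of the two measured compounds, and the one step available, an at least 5.0-fold higher number from compound 1 to compound 2 (0.69 log units; beyond the scatter), tells only how far it falls short of compound 1.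

Compound 3, `CNC(=O)[C@H]1CC[C@@H](Nc2cc(NCc3cnccc3C(F)(F)F)ncc2C#N)CC1`, is the next compound to be tested. It differs from compound 2 by 4-(methylcarbamoyl)cyclohexyl in place of (4-methoxycyclohexyl)methyl on a nitrogen on an aromatic ring. Within the data shown here, the only measured step concerns a different change, the methyl on the oxygen, so it gives no direct guide to this swap. The entering group restores a hydrogen-bond donor, which compound 1 also carried, while the linker between ring and aromatic nitrogen is shortened.

Compound 3 is expected to sit between the two measured values, around 5000 nM in this assay, with a plausible range of 1000 nM to 20000 nM. That estimate means a step of an at least 2.0-fold lower number from compound 2 to compound 3 (0.30 log units; that floor lies within the scatter), and a real chance remains that compound 3 again gives only a limit.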

Compound 3, half-maximal inhibitory concentration: 1600 nM
Compound 3: middle estimate off by 3.1-fold (0.49 log units), on the high side; measured number inside the range.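

On a nitrogen on an aromatic ring, 4-(methylcarbamoyl)cyclohexyl gives a measured number in this assay where (4-methoxycyclohexyl)methyl did not, with an at least 6.2-fold lower number from compound 2 to compound 3 (0.79 log units; beyond the scatter). That step is only a floor, since the value of compound 2 is a limit of the assay and not a number: the limit of > 10000 nM in this assay, at which 1 of the 3 values shown sits. The other comparison is a 1.3-fold lower number from compound 1 to compound 3 (0.10 log units; within the scatter), so (4-hydroxycyclohexyl)methyl and 4-(methylcarbamoyl)cyclohexyl cannot be told apart here, although they differ both in the end group and in how the cyclohexyl ring is joined to the nitrogen, and across these few compounds the two arms that carry a hydrogen-bond donor give numbers while the one without gives a limit.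

Compound 3 differs from compound 2 in the end group and in the link to the nitrogen at once, so the compounds shown cannot separate what each of these changes contributes. An arm such as 4-(dimethylcarbamoyl)cyclohexyl, which has no amide hydrogen, or (4-(methylcarbamoyl)cyclohexyl)methyl, which keeps the amide and restores the longer link, would test each part alone.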